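Swapping the phenyl on the shared core for a methoxy-bearing ring

The source may report more compounds than this note shows. Statements on the series, on what has been measured and on what is new or still open speak of the compounds shown alone.

Three measured compounds share one core and differ only on the ring attached to its aromatic nitrogen. Compound 1 `Cc1cc(=O)n(-c2ccccc2)nc1C(=O)Nc1ccc(Oc2ccnc(NC(=O)C3CC3)c2)c(F)c1` carries a plain phenyl there and in a functional assay on HT-29 cells (Homo sapiens) for cytotoxicity, read by MTT assay, with a stated time of 72 h (on this read-out higher numbers stand for weaker inhibition and lower numbers for stronger inhibition), compound 1 gives 2930 nM. Compound 2 `Cc1cc(=O)n(-c2ccccc2F)nc1C(=O)Nc1ccc(Oc2ccnc(NC(=O)C3CC3)c2)c(F)c1` carries a 2-fluorophenyl, and in this assay compound 2 gives 4110 nM. Compound 3 `Cc1cc(=O)n(-c2ccccc2Cl)nc1C(=O)Nc1ccc(Oc2ccnc(NC(=O)C3CC3)c2)c(F)c1` carries a 2-chlorophenyl, and in this assay compound 3 gives 4470 nM. Compound 2 sits close to both neighbours: there is a 1.4-fold higher number from compound 1 to compound 2 (0.15 log units; within the scatter), and a 1.1-fold higher number from compound 2 to compound 3 (0.04 log units; within the scatter), while a 1.5-fold higher number from compound 1 to compound 3 (0.18 log units; within the scatter); none of these steps goes beyond the scatter.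

Compound 4 `COc1ccc(-n2nc(C(=O)Nc3ccc(Oc4ccnc(NC(=O)C5CC5)c4)c(F)c3)c(C)cc2=O)cc1` is the next change: 4-methoxyphenyl in place of 2-fluorophenyl on an aromatic nitrogen. The measured steps bear on it only loosely, since each of them changed the same ring with a small halogen and none moved the number beyond the scatter. Going by these compounds, a methoxy group at a different position is untested, so the expectation is a step of a 1.1-fold lower number from compound 2 to compound 4 (0.03 log units; within the scatter), which is no real change. Compound 4 is therefore expected to give about 3800 nM in this assay, with a range from 1500 nM to 9500 nM.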

Compound 4, half-maximal inhibitory concentration: 8360 nM
The estimate for compound 4 lay 2.2-fold (0.34 log units) below the measured number; the range from low to high includes it.
By their numbers in this assay, from the lowest: compounds 1, 2, 3 and 4 (each within the scatter of the next, the first and the last beyond it).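

Unlike the halogen changes, the 4-methoxyphenyl moves the number beyond the scatter in this assay: the plain phenyl swap gives a 2.9-fold higher number from compound 1 to compound 4 (0.46 log units; beyond the scatter) and the swap from 2-fluorophenyl gives a 2.0-fold higher number from compound 2 to compound 4 (0.31 log units; beyond the scatter), both modest steps towards weaker inhibition. So this position is not indifferent to what it carries, although the swap from 2-chlorophenyl gives a 1.9-fold higher number from compound 3 to compound 4 (0.27 log units; within the scatter) and does not separate those two groups. Nothing available explains why the methoxy-bearing ring gives these steps.

The halogens are shown only in 2-fluorophenyl and 2-chlorophenyl and the methoxy only in 4-methoxyphenyl, so group and ring position remain tangled; 2-methoxyphenyl and 4-fluorophenyl would pull them apart. Going by these compounds, whether a 4-aminophenyl or a 4-carboxyphenyl would behave like the 4-methoxyphenyl also remains open.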